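Methyl on the Ring Amide Nitrogen: An Expected Loss

A few compounds are considered here, and "the series" means these few. Any claim that something is new, unique, unknown or untested is made for them only; others in the source may bear on it.

Compound 1 `Cc1ccc(/C=C2\CN(C)C[C@@]3(C2=O)[C@@H](c2ccc(C)cc2)CN(C)[C@@]32C(=O)Nc3ccccc32)cc1` gives 69.2%
Compound 2 `Cc1ccc(/C=C2\CN(C)C[C@@]3(C2=O)[C@@H](c2ccc(C)cc2)CN(C)[C@@]32C(=O)N(C)c3ccccc32)cc1` gives 53.5%
Compound 3 `CN1C/C(=C\c2ccc(-c3cccs3)cc2)C(=O)[C@]2(C1)[C@@H](c1ccc(-c3cccs3)cc1)CN(C)[C@@]21C(=O)Nc2ccccc21` gives 68%

All three were tested in a functional assay on the whole organism (strain Wister albino) for inhibition, with Rattus norvegicus as the target, read by paw edema, with a stated time of 1 h, at a dose of 50 mg/kg by the intraperitoneal route; a higher number here means more inhibition at the dose given (going by the name of the read-out), a lower number less inhibition. Compound 1 and compound 2 share one core and differ in a single place: methyl in place of hydrogen on an amide-type nitrogen in a ring. That change gave a number 15.7 percentage points lower from compound 1 to compound 2 (beyond the scatter), so the methyl on the ring amide nitrogen cost a clear part of the inhibition in this pair.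

Compound 3 carries a different core; how its core differs from that of compound 1 is not broken down here. Its value and that of compound 1 lie within the scatter of each other, so nothing can be said about their order. Compound 2 stands lower than compound 3, beyond the scatter.

Compound 4 `CN1C/C(=C\c2ccc(-c3cccs3)cc2)C(=O)[C@]2(C1)[C@@H](c1ccc(-c3cccs3)cc1)CN(C)[C@@]21C(=O)N(C)c2ccccc21` has not yet been measured. It relates to compound 3 exactly as compound 2 relates to compound 1: methyl in place of hydrogen on an amide-type nitrogen in a ring, at the same kind of place in the same words. Among the compounds with values here, only one measured example of this change exists, so the expectation rests on it alone. The step from compound 3 to compound 4 is estimated as a number 16 percentage points lower from compound 3 to compound 4 (beyond the scatter), taken over from compound 1 to compound 2, which showed a number 15.7 percentage points lower from compound 1 to compound 2 (beyond the scatter). Compound 4 is therefore expected to give about 52%, with a likely span from 40% to 64%.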

Compound 4, a percentage reported as inhibition, in the whole organism at one dose (the size of the read-out at that dose, not a potency): 84.7%
Compound 4: the middle estimate sits 32.7 percentage points below what was measured; the measured number lies above the stated range.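

On the core of compound 3, in this assay, putting methyl in place of the amide hydrogen gave a number 16.7 percentage points higher from compound 3 to compound 4 (beyond the scatter), so the same small change that lowered the number on the core of compound 1 raised it here. Set side by side, the two steps do not agree, and the gap between them is larger than repeated measurements would explain: the same change on two cores in this assay, a number 15.7 percentage points lower (beyond the scatter) from compound 1 to compound 2 and a number 16.7 percentage points higher (beyond the scatter) from compound 3 to compound 4, 32.4 percentage points apart, beyond the scatter of two such steps. Within the data shown here, this shows that, in this series, the step measured on one core cannot simply be carried over to the other, and even its direction did not hold, but with only two pairs it does not show which part of the cores matters, why the direction reversed, or which result would be the more typical on a third core.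

The compounds shown leave open how a longer chain, such as ethyl or propyl, on the same amide nitrogen would behave on each of the two cores, and whether it would follow the methyl step on both. They also leave open whether the opposite steps would persist at other doses and times, since each compound appears here at a single dose and a single time.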